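The compounds below may be only part of what the source reports. "The series", "measured", "known", "first", "only" and "open" are said of these compounds alone.

Measured in an ADME assay for lipophilicity; on this read-out higher numbers stand for higher lipophilicity and lower numbers for lower lipophilicity:
Compound 1 `CCn1cccc(O)c1=O`: 0.2
Compound 2 `CCCn1cccc(O)c1=O`: 0.69

Of the two measured compounds, compound 2 stands higher, at 0.69, beyond the scatter from compound 1. Compound 3 `CCCCn1cccc(O)c1=O` differs from compound 2 by methyl in place of hydrogen on a saturated chain carbon, three bonds along the chain from an aromatic nitrogen, which reads as propyl to butyl. For the measured compounds named here, only one measured step bears on this change, the modest rise a number 0.49 log units higher from compound 1 to compound 2 (beyond the scatter), where methyl replaced hydrogen two bonds along the chain from an aromatic nitrogen. A rise of similar size is therefore expected in this assay, the expected step being a number 0.51 log units higher from compound 2 to compound 3 (beyond the scatter). For compound 3 the estimate is 1.2, with an expected range of 0.9 to 1.5.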

Compound 3, distribution coefficient: 1.18
For compound 3 the middle estimate is 0.02 log units above the measured one; low and high end bracket the measured number.
By their numbers in this assay, from the lowest: compound 1; then compound 2; then compound 3.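

In this assay the newly added methyl counts as much as the one before it: propyl to butyl gives a number 0.49 log units higher from compound 2 to compound 3 (beyond the scatter), a step of the same size as a number 0.49 log units higher from compound 1 to compound 2 (beyond the scatter). Together the two steps amount to a number 0.98 log units higher from compound 1 to compound 3 (beyond the scatter), so across these three compounds the number rises evenly with chain length, and none goes against this. Nothing shown here accounts for that rise. From the compounds shown here alone, whether it carries on to a longer chain such as pentyl or hexyl stays open. So does the effect of a branched chain, or of an amine or a carboxylic acid on the chain.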